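Replacing a Saturated Side Chain with an Aromatic Pyridine

The source may hold more compounds than are shown below. What is called first, only, known or untested is meant among the compounds shown, and "the series" means these compounds.

The compounds here share one core and differ only in their side groups. Going by the values given here, in an ADME assay on MRC5 cells (Homo sapiens) for inhibition, with a stated time of 72 h (on this read-out lower numbers stand for an effect already at smaller amounts and higher numbers for an effect only at larger amounts of compound), compound 1 `CO[C@H]1CC[C@H](NC(=O)c2n[nH]cc2NC(=O)c2ccc(OC(F)F)cc2)CC1` gives 2500 nM, and compound 2 `CO[C@H]1CC[C@H](NC(=O)c2n[nH]cc2NC(=O)c2ccccc2)CC1` gives 800 nM; the single measured step, a 3.1-fold lower number from compound 1 to compound 2 (0.49 log units; beyond the scatter), concerns a different part of the molecule. Compound 3 `COc1cccc(OC)c1C(=O)Nc1c[nH]nc1C(=O)NCC1CCCCC1` gives > 50000 nM in this assay, which is a limit of the assay and not a number. Compound 3 thus stands at the limit of > 50000 nM in this assay, at which 1 of the 3 values shown sits. Compound 4 `COc1cccc(OC)c1C(=O)Nc1c[nH]nc1C(=O)Nc1ccncc1` carries pyridin-4-yl in place of cyclohexylmethyl on an amide-type nitrogen. Among the compounds with values here, no measured step covers this change, and the step from compound 1 to compound 2 tells nothing about it. The step that the limit leaves unreadable from compound 3 to compound 4 is therefore expected to be small, likely none beyond the scatter. Compound 4 is estimated at 60000 nM, within a range from 12000 nM to 300000 nM.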

Compound 4, half-maximal effective concentration: > 50000 nM
Compound 4: no number, only a limit (the forecaster's own chance of this, stated with the estimate: 60%); the middle value is on the limit's open side.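

Compound 3 and compound 4 both give a limit of the assay and not a number, so no step between them can be read: the limit of > 50000 nM in this assay, at which 2 of the 4 values shown sit.

The compounds shown leave open how much pyridin-4-yl in place of cyclohexylmethyl changes the read-out.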